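Changing the amide substituent of compound 1

The compounds below may be only part of what the source reports. "The series", "measured", "known", "first", "only" and "open" are said of these compounds alone.

Measured in a functional assay on A549 cells (Homo sapiens) for cytotoxicity, read by MTT assay, with a stated time of 72 h; a higher number here means a weaker inhibitor, a lower number a stronger inhibitor:
- compound 1 `O=C(CN1CCN(c2nnc(Cc3ccccc3)c3ccccc23)CC1)Nc1c(F)cccc1F`: 84500 nM
- compound 2 `Cc1ccc(NC(=O)CN2CCN(c3nnc(Cc4ccncc4)c4ccccc34)CC2)c(C)c1`: 45000 nM
- compound 3 `O=C(CN1CCN(c2nnc(Cc3ccncc3)c3ccccc23)CC1)Nc1cccc(F)c1`: 4600 nM

Compound 1, at 84500 nM, lies within the usual scatter of compound 2, at 45000 nM. Both numbers are higher, beyond the scatter, than that of compound 3, at 4600 nM. A higher number here means a weaker inhibitor, so compound 1 sits in the weak group of this small set.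

Compound 4 `O=C(CN1CCN(c2nnc(Cc3ccccc3)c3ccccc23)CC1)Nc1cc(C(F)(F)F)ccc1Cl` keeps the core of compound 1 and changes one group on the amide-type nitrogen: 2-chloro-5-(trifluoromethyl)phenyl in place of 2,6-difluorophenyl on an amide-type nitrogen. In short, 2-chloro-5-(trifluoromethyl)phenyl takes the place of 2,6-difluorophenyl.

For the measured compounds named here, one measured step bears on this: a 9.8-fold lower number from compound 2 to compound 3 (0.99 log units; beyond the scatter). It shows that exchanging the group at this nitrogen can matter in this assay. It is only a rough guide, however, since the compounds in that step differ from compound 1 elsewhere and neither group involved here appears in it. No measurement shows the direction for this exchange. Still, compound 1 at 84500 nM has more measured room downward, so a modest fall is the cautious expectation. The expected change is a 2.4-fold lower number from compound 1 to compound 4 (0.38 log units; beyond the scatter), an estimate that could fall within the scatter. Compound 4 is estimated at 35000 nM, with an expected range from 7000 nM to 130000 nM.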

Compound 4, half-maximal inhibitory concentration: 89000 nM
Beside the measured number, compound 4's estimate is 2.5-fold (0.41 log units) below it; low and high end bracket the measured number.
By their numbers in this assay, from the lowest: compound 3; then compounds 2, 1 and 4 (each within the scatter of the next).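

In this assay, the exchange of 2,6-difluorophenyl for 2-chloro-5-(trifluoromethyl)phenyl on the amide-type nitrogen gives a 1.1-fold higher number from compound 1 to compound 4 (0.02 log units; within the scatter) on the core of compound 1. The incoming group carries more heavy atoms, including chlorine, and a different arrangement of substituents on its ring, yet this change leaves the number within the scatter. The earlier step, a 9.8-fold lower number from compound 2 to compound 3 (0.99 log units; beyond the scatter) on a different core, showed that a change at this nitrogen can matter, whereas this step shows that not every such exchange does, and no available evidence explains why these two groups read alike.

Whether the 3-fluorophenyl group of compound 3 would lower the number on the core of compound 1 as well, or whether 2-chloro-5-(trifluoromethyl)phenyl would behave the same way on the core of compound 3, remains an open question. The compounds shown also leave open what would happen with a carboxylic acid or an amine on the aromatic ring, or with a longer carbon chain on the amide-type nitrogen in place of the ring.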